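Trimming the Ring a Second Time on a Difluoro Core

This account rests on a few compounds, and the source may have more. Where it says the series, first, only, none or still open, it means among the compounds named here.

Compound 1 `C[C@H]1[C@@H](N)CN1c1cc2c(cc1F)c(=O)c(C(=O)O)cn2C1CC1` gives 6.1 ug/mL in a physicochemical assay for solubility, at pH 7.4; on this read-out lower numbers stand for lower solubility and higher numbers for higher solubility.
Compound 2 `C[C@H]1N(c2c(F)cc3c(=O)c(C(=O)O)cn(C4CC4)c3c2F)C[C@]1(C)N` gives 3.3 ug/mL in this assay.
Compound 3 `C[C@H]1N(c2cc3c(cc2F)c(=O)c(C(=O)O)cn3C2CC2)C[C@]1(C)N` gives 1.3 ug/mL in this assay.

Compound 1 and compound 3 differ in one place: a group of 6 heavy atoms (4 carbon, 2 nitrogen; one four-membered non-aromatic ring with 1 hetero atom) in place of a group of 7 heavy atoms (5 carbon, 2 nitrogen; one four-membered non-aromatic ring with 1 hetero atom), on an aromatic carbon. That change produced a 4.7-fold higher number from compound 3 to compound 1 (0.67 log units; beyond the scatter). Compound 2 and compound 3 carry the same group and differ only in the core: fluoro in place of hydrogen on an aromatic carbon. Here the numbers show a 2.5-fold lower number from compound 2 to compound 3 (0.40 log units; beyond the scatter). The values of compound 1 and compound 2 lie within the scatter of each other, so no order can be read from them.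

Compound 4 `C[C@H]1[C@@H](N)CN1c1c(F)cc2c(=O)c(C(=O)O)cn(C3CC3)c2c1F` has not been measured. It differs from compound 2 in one place: a group of 6 heavy atoms (4 carbon, 2 nitrogen; one four-membered non-aromatic ring with 1 hetero atom) in place of a group of 7 heavy atoms (5 carbon, 2 nitrogen; one four-membered non-aromatic ring with 1 hetero atom), on an aromatic carbon. For the measured compounds named here, this is the same kind of change as the one from compound 3 to compound 1, not the same change: in compound 3 the place is ortho to a fluoro group, whereas in compound 2 it is ortho to two fluoro groups. The same kind of change occurs twice among the compounds shown, once measured and once not.

Because the measured example gave a 4.7-fold higher number from compound 3 to compound 1 (0.67 log units; beyond the scatter), the step from compound 2 to compound 4 is expected to be about a 3.9-fold higher number from compound 2 to compound 4 (0.60 log units; beyond the scatter). The range is kept wide since the two places are not the same word for word. On that footing compound 4 is expected to give roughly 13 ug/mL in this assay, likely falling from 5 ug/mL to 32 ug/mL.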

Compound 4, solubility: 23.6 ug/mL
Beside the measured number, compound 4's estimate is 1.8-fold (0.26 log units) below it, within the range that was stated.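

In this assay, putting the smaller four-membered ring group in place of the larger one gave a 7.2-fold higher number from compound 2 to compound 4 (0.85 log units; beyond the scatter), and the same kind of change on the other core gave a 4.7-fold higher number from compound 3 to compound 1 (0.67 log units; beyond the scatter); both steps are beyond the usual scatter and point the same way. With the smaller group in place on both compounds, fluoro in place of hydrogen gave a 3.9-fold higher number from compound 1 to compound 4 (0.59 log units; beyond the scatter), which matches the direction of a 2.5-fold lower number from compound 2 to compound 3 (0.40 log units; beyond the scatter), where hydrogen replaces fluoro with the larger group in place. These two cores show that the change carried over in direction between them, but two examples set no rule for any other core, and nothing measured here bears on what lies behind the rise in these numbers.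

The compounds shown leave open whether the step would keep its direction with a chloro or methoxy group in place of the added fluoro on the core. They also leave open what would happen if a longer chain ending in an amine took the place of the four-membered ring group.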